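Notes on compound 4 in the diphenylacetamide series

The source may hold more compounds than are shown below. What is called first, only, known or untested is meant among the compounds shown, and "the series" means these compounds.

Measured so far in an assay on CHO cells for inhibition of sodium channel protein type 2 subunit alpha (Rattus norvegicus); a higher number here means a weaker inhibitor, a lower number a stronger inhibitor:
- compound 1 `CC1CCC(C)N1CCCNC(=O)C(c1ccccc1)c1ccccc1`: 4600 nM
- compound 2 `O=C(NCCCN1CCC(c2ccccc2)CC1)C(c1ccccc1)c1ccccc1`: 1100 nM
- compound 3 `CC(CNC(=O)C(c1ccccc1)c1ccccc1)CN1CCC(c2ccccc2)CC1`: 1500 nM

Compound 2 gives the lowest number of the three. Its nearest neighbour is compound 3, and the step of a 1.4-fold higher number from compound 2 to compound 3 (0.13 log units; within the scatter) stays within the scatter, so the two cannot be ordered. Compound 1 lies furthest away; its value and that of compound 2 differ by more than the scatter, so the change of the saturated ring system between compound 1 and compound 2 is the only shift of substance seen here. Within the data shown here, no step between these two is tabulated, so only the two numbers speak.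

Compound 4 `O=C(NCCCN1CCC(n2c(O)nc3ccccc32)CC1)C(c1ccccc1)c1ccccc1` is made from compound 2 by the change (2-hydroxy-1H-benzimidazol-1-yl in place of phenyl on a saturated ring carbon). Among the measured compounds shown here, no measured pair touches this kind of replacement: the one tabulated step, a 1.4-fold higher number from compound 2 to compound 3 (0.13 log units; within the scatter), concerns a methyl on the chain and lies within the scatter, so it carries no information on the ring substituent. With the saturated ring kept as in compound 2 and a larger, donor- and acceptor-bearing group in place of the phenyl, the direction is open; a step in this assay of modest size toward a higher number is expected, but a flat outcome within the scatter cannot be excluded.

Compound 4 is therefore estimated at 2500 nM (range 600 nM to 10000 nM), which means an expected step of a 2.3-fold higher number from compound 2 to compound 4 (0.36 log units; beyond the scatter).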

Compound 4, half-maximal inhibitory concentration: 720 nM
For compound 4 the middle estimate is 3.5-fold (0.54 log units) above the measured one; the measured number falls inside the stated range.
By their numbers in this assay, from the lowest: compounds 4, 2 and 3 (each within the scatter of the next, the first and the last beyond it); then compound 1.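

Placing 2-hydroxy-1H-benzimidazol-1-yl in place of phenyl on the saturated ring carbon gives, in this assay, a 1.5-fold lower number from compound 2 to compound 4 (0.18 log units; within the scatter), so the two compounds cannot be ordered. The earlier compounds shown here spoke only to a methyl on the chain and to a change of the saturated ring system; this pair adds that, at this ring carbon, a group with a second aromatic ring, more heavy atoms, a hydrogen-bond donor and hydrogen-bond acceptors can replace phenyl without a step beyond the scatter. No evidence bearing on the reason for this result is at hand.

The compounds shown leave open whether this holds for other kinds of substituent at the same ring carbon, such as a primary amine or a carboxylic acid, and whether the hydroxy group of the entering group matters, which a methoxy group in its place would test. Also open, on these data alone, is whether the chain methyl of compound 3 and the 2-hydroxy-1H-benzimidazol-1-yl group can be combined in one compound without a step beyond the scatter.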